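Swapping the basic amine for a hydroxyl on the side chain

A few compounds are considered here, and "the series" means these few. Any claim that something is new, unique, unknown or untested is made for them only; others in the source may bear on it.

Measured compounds:
- compound 1, `Cn1c(N)c(-c2nc3ccccc3[nH]2)c2nc(C#N)c(C#N)nc21`: > 50000 nM
- compound 2, `CN(C)CCn1c(N)c(-c2nc3ccccc3[nH]2)c2nc(C#N)c(C#N)nc21`: 9730 nM
- compound 3, `CN1CCN(CCn2c(N)c(-c3nc4ccccc4[nH]3)c3nc(C#N)c(C#N)nc32)CC1`: 10900 nM

The three measured compounds share one core and differ only in the chain on the aromatic nitrogen. In an ADME assay on HEK293 cells (Homo sapiens) for cytotoxicity, read by MTT assay, with a stated time of 48 h (on this read-out lower numbers stand for stronger inhibition and higher numbers for weaker inhibition), compound 1 gives > 50000 nM, which is a limit of the assay rather than a number. Compound 2 gives 9730 nM in this assay, and compound 3 gives 10900 nM. Among the two real numbers, compound 2 holds the lower one, but the gap to compound 3 is a 1.1-fold higher number from compound 2 to compound 3 (0.05 log units; within the scatter), so the two cannot be ordered. The step of an at least 5.1-fold lower number from compound 1 to compound 2 (0.71 log units; beyond the scatter) is clear, as is an at least 4.5-fold lower number from compound 1 to compound 3 (0.66 log units; beyond the scatter), both following the addition of a basic chain.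

Compound 4, `N#Cc1nc2c(-c3nc4ccccc4[nH]3)c(N)n(CCCO)c2nc1C#N`, is not yet measured. It differs from compound 2 by hydroxymethyl in place of dimethylamino on a saturated chain carbon, two bonds along the chain from an aromatic nitrogen. The change removes the dimethylamino that distinguished compound 2 from compound 1, and the step from compound 1 to compound 2 is the one that bears on it; the step from compound 2 to compound 3 suggests that exchanging one basic amine for another changes little. Without a basic amine, compound 4 is expected to move back part of the way toward compound 1, so a higher number in this assay is expected, roughly a 3.1-fold higher number from compound 2 to compound 4 (0.49 log units; beyond the scatter). Compound 4 is therefore estimated at 30000 nM, with a range from 10000 nM to 90000 nM, and a real chance that only a limit is reported.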

Compound 4, half-maximal inhibitory concentration: > 50000 nM
Compound 4 was reported as a limit; the forecaster's own chance of this, stated with the estimate: 40%; at least 1.6-fold (0.22 log units) between middle value and limit.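

Exchanging dimethylamino for hydroxymethyl on a saturated chain carbon, two bonds along the chain from an aromatic nitrogen, gives an at least 5.1-fold higher number from compound 2 to compound 4 (0.71 log units; beyond the scatter) in this assay, and the comparison with the piperazine chain gives an at least 4.5-fold higher number from compound 3 to compound 4 (0.66 log units; beyond the scatter). The earlier compounds could not separate the chain from the amine it carries, whereas compound 4 shows that a chain as such, here 3-hydroxypropyl, does not bring the lower numbers seen for compound 2 and compound 3, and no compound shown goes against this. Compound 1 and compound 4 are both reported only as a limit, and the step between them cannot be read: the limit of > 50000 nM in this assay, at which 2 of the 4 values shown sit.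

From the compounds shown here alone, how far the true value of compound 4 lies beyond that limit remains open. Also open, going by these compounds, is whether a primary amine, a morpholine or a carboxylic acid at the end of this chain, or a longer chain ending in dimethylamino, would give a number near that of compound 2.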